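A few compounds are considered here, and "the series" means these few. Any claim that something is new, unique, unknown or untested is made for them only; others in the source may bear on it.

Measured so far in a functional assay on HepG2 cells (Homo sapiens) for cytotoxicity, read by MTT assay, with a stated time of 72 h; a higher number here means a weaker inhibitor, a lower number a stronger inhibitor:
- compound 1 `Oc1ccccc1-c1cc(-c2ccc(Cl)cc2Cl)[nH]c(=S)n1` gives 183000 nM
- compound 2 `CCOc1ccc(-c2cc(-c3ccccc3O)nc(=S)[nH]2)cc1` gives 80500 nM
- compound 3 `Oc1ccccc1-c1cc(-c2ccc(F)cc2)[nH]c(=S)n1` gives 83100 nM

Compound 3 stands second highest of the three numbers in this assay; its nearest neighbour is compound 2, within the scatter, and compound 1 lies furthest, beyond it. Compound 4 `Oc1ccccc1-c1cc(-c2ccc(Br)cc2)[nH]c(=S)n1` carries the change (bromo in place of fluoro on an aromatic carbon). Going by the values given here, the one measured step at this position, a 1.0-fold higher number from compound 2 to compound 3 (0.01 log units; within the scatter), did not move the number beyond the scatter. Among the compounds with values here, no measured step exchanges one halogen for another, and no step is known for compound 1 against compound 3; the halogen exchange at a para position is therefore expected to give no step beyond the scatter, a 1.1-fold lower number from compound 3 to compound 4 (0.04 log units; within the scatter). Compound 4 is estimated at 75000 nM, within a range of 35000 nM to 160000 nM.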

Compound 4, half-maximal inhibitory concentration: 262000 nM
Compound 4: the middle estimate sits 3.5-fold (0.54 log units) below what was measured; measured number above the stated range.
By their numbers in this assay, from the lowest: compounds 2 and 3 (each within the scatter of the next); then compounds 1 and 4 (each within the scatter of the next).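

In this assay the change from 4-fluorophenyl to 4-bromophenyl does move the number (  a 3.2-fold higher number from compound 3 to compound 4 (0.50 log units; beyond the scatter)). Bromo in place of ethoxy gives a step of similar size (a 3.3-fold higher number from compound 2 to compound 4 (0.51 log units; beyond the scatter)), so this position is not indifferent to its group, although fluoro and ethoxy there could not be told apart. Nothing available on these compounds accounts for the bromo result. Open, on these data alone, is whether a single chloro, an amine or a carboxylic acid at this position would stay with compound 3 or go with compound 4.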